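Aryl swap on the ring nitrogen: methoxy to dimethyl

The source may report more compounds than this note shows. Statements on the series, on what has been measured and on what is new or still open speak of the compounds shown alone.

Compound 1 `N#CC1=C(N)Oc2c(N)cc3nc4ccccc4nc3c2C12C(=O)N(Cc1cnnn1-c1ccccc1Cl)c1ccccc12` gives 34400 nM in a functional assay on MCF7 cells (Homo sapiens) for antiproliferative activity, read by MTT assay, with a stated time of 48 h; on this read-out lower numbers stand for stronger inhibition and higher numbers for weaker inhibition.
Compound 2 `N#CC1=C(N)Oc2c(N)cc3nc4ccccc4nc3c2C12C(=O)N(Cc1cnnn1-c1cccc(C(F)(F)F)c1)c1ccccc12` gives 31600 nM.
Compound 3 `COc1ccc(-n2nncc2CN2C(=O)C3(C(C#N)=C(N)Oc4c(N)cc5nc6ccccc6nc5c43)c3ccccc32)cc1` gives only > 50000 nM, which is a limit of the assay.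

Compound 3 thus stands at the limit of > 50000 nM in this assay, at which 1 of the 3 values shown sits, and its number is not known beyond that. The change to compound 4 `Cc1ccc(-n2nncc2CN2C(=O)C3(C(C#N)=C(N)Oc4c(N)cc5nc6ccccc6nc5c43)c3ccccc32)cc1C` is 3,4-dimethylphenyl in place of 4-methoxyphenyl on an aromatic nitrogen. Among the compounds with values here, three measured steps bear on it, each exchanging the aryl on the aromatic nitrogen: a 1.1-fold lower number from compound 1 to compound 2 (0.04 log units; within the scatter), an at least 1.4-fold higher number from compound 1 to compound 3 (0.16 log units; that floor lies within the scatter) and an at least 1.5-fold higher number from compound 2 to compound 3 (0.19 log units; that floor lies within the scatter). None of them exceeds the scatter, so no step beyond the scatter is expected from compound 3 to compound 4, an at least 1.1-fold lower number from compound 3 to compound 4 (0.04 log units; that floor lies within the scatter). Compound 4 is therefore estimated at 45000 nM, with a range from 20000 nM to 90000 nM, and with a fair chance that this assay again reports only a limit.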

Compound 4, half-maximal inhibitory concentration: > 50000 nM
Compound 4: a limit, no number; the forecaster's own chance of this, stated with the estimate: 45%; middle value at least 1.1-fold (0.04 log units) from the limit.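

In this assay, compound 4 gives a limit and not a number, as compound 3 does, so the step between them cannot be read. Within the data shown here, the only readable steps are floors: an at least 1.5-fold higher number from compound 2 to compound 4 (0.19 log units; that floor lies within the scatter), and an at least 1.4-fold higher number from compound 1 to compound 4 (0.16 log units; that floor lies within the scatter). A second aryl group on this aromatic nitrogen, here without the oxygen of 4-methoxyphenyl, now sits at the same limit: the limit of > 50000 nM in this assay, at which 2 of the 4 values shown sit.

Going by these compounds, how far compound 3 and compound 4 lie past that limit stays open. So does whether a phenyl bearing an amine or a carboxylic acid would give a value clearly apart from compound 1.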